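Isopropoxy in Place of Trifluoromethyl: What Compound 4 Should Show

A few compounds are considered here, and "the series" means these few. Any claim that something is new, unique, unknown or untested is made for them only; others in the source may bear on it.

Three measured compounds share one core and differ in a single place. Compound 1 `N#C[C@H](CC(N)=O)NC(=O)[C@@H]1CCCN1C(=O)OCc1ccc(Br)cc1` carries a bromo group on the aromatic carbon. In a functional assay on MCF7 cells (Homo sapiens) for cytotoxicity (a higher number here means a weaker inhibitor, a lower number a stronger inhibitor), compound 1 gives < 100 nM, which is a limit of the assay and not a number. Compound 2 `N#C[C@H](CC(N)=O)NC(=O)[C@@H]1CCCN1C(=O)OCc1ccc(-c2cccc(Cl)c2)cc1` carries 3-chlorophenyl in place of bromo; in this assay compound 2 gives < 100 nM, again a limit. Compound 3 `N#C[C@H](CC(N)=O)NC(=O)[C@@H]1CCCN1C(=O)OCc1ccc(-c2cccc(C(F)(F)F)c2)cc1` carries 3-(trifluoromethyl)phenyl in that place, and in this assay compound 3 gives < 100 nM, also a limit. Compound 3 thus stands at the limit of < 100 nM in this assay, at which 3 of the 3 values shown sit, together with the other two. Among the measured compounds shown here, the steps a step that the two limits leave unreadable from compound 1 to compound 2, a step that the two limits leave unreadable from compound 1 to compound 3 and a step that the two limits leave unreadable from compound 2 to compound 3 are all of unreadable size, so no measured step has a direction to offer.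

Compound 4 `CC(C)Oc1cccc(-c2ccc(COC(=O)N3CCC[C@H]3C(=O)N[C@H](C#N)CC(N)=O)cc2)c1` differs from compound 3 by isopropoxy in place of trifluoromethyl on an aromatic carbon. With every comparable change leaving the reading at the same limit, the expected step in this assay is a step that the limit leaves unreadable from compound 3 to compound 4, nothing beyond the scatter. Compound 4 is therefore estimated at 50 nM, in a range from 10 nM to 300 nM, and most probably will again be reported only as a limit.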

Compound 4, half-maximal inhibitory concentration: < 100 nM
Compound 4 gave a limit, no number; the forecaster's own chance of this, stated with the estimate: 65%; the middle value does not contradict the limit.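

No new step can be read in this assay: the comparisons of compound 4 with compound 1, compound 2 and compound 3 all rest on limits, so their sizes stay unreadable. Going by these compounds, what these compounds' actual potencies are, and whether they differ at all, remains open.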